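This account rests on a few compounds, and the source may have more. Where it says the series, first, only, none or still open, it means among the compounds named here.

Going by the values given here, in an ADME assay on CEMx174 cells (Homo sapiens) for cytotoxicity (a higher number here means that more compound is tolerated, a lower number that less compound is tolerated), neither of the two compounds read so far gives a number. Compound 1 `O=C1NC(CCl)=C(C(=O)OCC2CCCCC2)C(c2cccc(O)c2)N1` gives > 3000 nM, which is a limit. Compound 2 `CCC1=C(C(=O)OCC2CCCCC2)C(c2ccc(O)cc2)NC(=O)N1` gives > 10000 nM, also a limit, and this is all that is known of its standing in the series. Compound 3 `CCC1=C(C(=O)OCC2CCCCC2)C(c2cccc(N)c2)NC(=O)N1` differs from compound 2 in one place, with 3-aminophenyl in place of 4-hydroxyphenyl on a saturated ring carbon. Among the compounds with values here, no measured step between compounds that differ in one place is available to guide the size of this change. In this assay, the expectation starts from the limit of compound 2, > 10000 nM, and no direction is favoured. The estimated step is a step that the limit leaves unreadable from compound 2 to compound 3. For compound 3 the expected value is 12000 nM, with an estimated range of 4000 nM to 30000 nM.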

Compound 3, half-maximal cytotoxic concentration: > 10000 nM
Compound 3: a limit, no number; the forecaster's own chance of this, stated with the estimate: 70%; the middle value is on the limit's open side.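

In this assay, going by these compounds alone, compound 2 and compound 3 both stand as limits, so no step between them can be read. The compounds shown leave open where either true value lies, and whether 3-aminophenyl in place of 4-hydroxyphenyl on a saturated ring carbon changes tolerance at all.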